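The source may hold more compounds than are shown below. What is called first, only, known or untested is meant among the compounds shown, and "the series" means these compounds.

Compound 1 `Oc1nc2nonc2nc1Nc1ccc(OCC(F)(F)F)cc1` and compound 2 `CCCCc1ccc(Nc2nc3nonc3nc2O)cc1` share one core and differ only in the group carried on an aromatic carbon of the outer ring. In an assay on mitochondria from L6 cells (Rattus norvegicus) for activation, with a stated time of 90 min (on this read-out lower numbers stand for an effect already at smaller amounts and higher numbers for an effect only at larger amounts of compound), compound 1 gives 42300 nM, whereas compound 2 gives 2100 nM. Among the compounds with values here, the step of a 20-fold lower number from compound 1 to compound 2 (1.30 log units; beyond the scatter) is the only one measured so far, so compound 2 stands at the lowest of the two numbers, with compound 1 as its only neighbour at a far higher number.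

Compound 3 `Oc1nc2nonc2nc1Nc1ccc(OC(F)(F)C(F)F)cc1` has not yet been tested in this assay. It changes compound 2 as follows: 1,1,2,2-tetrafluoroethoxy in place of butyl on an aromatic carbon. Within the data shown here, the group that enters resembles the one carried by compound 1, since both are fluorine-bearing ethoxy groups joined to the ring through oxygen. Among the measured compounds shown here, the single measured step that bears on this change is a 20-fold lower number from compound 1 to compound 2 (1.30 log units; beyond the scatter), and compound 3 reverses it in kind, going from butyl back to a fluorinated ethoxy group. A large move towards higher numbers is therefore expected, roughly undoing that gain, though the extra fluorine leaves the exact size open. Compound 3 is expected to give about 20000 nM, between 6000 nM and 60000 nM. The expected step is a 9.5-fold higher number from compound 2 to compound 3 (0.98 log units; beyond the scatter).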

Compound 3, half-maximal effective concentration: 7000 nM
Beside the measured number, compound 3's estimate is 2.9-fold (0.46 log units) above it; the measured number falls inside the stated range.
By their numbers in this assay, from the lowest: compound 2; then compound 3; then compound 1.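

Replacing butyl with 1,1,2,2-tetrafluoroethoxy on this aromatic carbon, para to a large group, gives a 3.3-fold higher number from compound 2 to compound 3 (0.52 log units; beyond the scatter) in this assay, so butyl still has the lowest number, but a fluorinated ethoxy group does not have to lose all of the ground that compound 1 suggested. The fluorinated groups are also not interchangeable: changing how the fluorine atoms are placed on the group joined through oxygen gives a 6.0-fold lower number from compound 1 to compound 3 (0.78 log units; beyond the scatter), a step beyond the usual scatter even though both groups are fluorine-bearing ethoxy groups. Nothing measured here explains why these groups differ in this way.

Butyl differs from both fluorinated groups in having neither oxygen nor fluorine, so the compounds shown leave open how much of the difference belongs to the oxygen link and how much to the fluorine atoms. A plain ethoxy group would help separate those two changes, while a longer chain such as hexyl would show whether numbers keep falling as the carbon chain grows beyond butyl.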